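Removing the Fluorophenyl Ring: An Untested Step

This account rests on a few compounds, and the source may have more. Where it says the series, first, only, none or still open, it means among the compounds named here.

Measured compounds:
compound 1, `CN(C)CCCCCSC1=Nc2ccccc2C(CC(=O)NCc2ccccc2)N1c1ccc(-c2ccc(F)cc2)cc1`, 66.7%
compound 2, `O=C(CC1c2ccccc2N=C(SCCCCCN2CCCC2)N1c1ccc(-c2ccc(F)cc2)cc1)NCc1ccccc1`, 68.2%

In an assay on cells for inhibition of Voltage-dependent T-type calcium channel subunit alpha-1I (Homo sapiens), read by patch clamp, tested at 10 uM (a higher number here means more inhibition at the concentration tested (going by the name of the read-out), a lower number less inhibition), compound 2 gives 68.2%, the higher of the two numbers recorded, though its neighbour compound 1 lies within the scatter of it: a number 1.5 percentage points higher from compound 1 to compound 2 (within the scatter). The two therefore cannot be ranked.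

Compound 3, `O=C(CC1c2ccccc2N=C(SCCCCCN2CCCC2)N1c1ccccc1)NCc1ccccc1`, has not yet been measured. It differs from compound 2 in one place: hydrogen in place of 4-fluorophenyl on an aromatic carbon.

Among the measured compounds shown here, the only measured step swaps one amine for another at the far end of the chain on the sulfur and leaves the aromatic rings untouched, so it tells nothing about what removing an entire ring from the aromatic ring on the nitrogen of the core does. For the measured compounds named here, no step in these data bears on this change. Dropping a ring of this size is a larger alteration than the one already seen, so a loss of inhibition beyond the scatter is considered more likely than a gain, but with wide uncertainty.

Compound 3 is therefore expected to give about 45% in this assay, in a range from 15% to 75%, which would mean an estimated step of a number 23.2 percentage points lower from compound 2 to compound 3 (beyond the scatter).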

Compound 3, a percentage reported as inhibition, at one concentration (the size of the read-out at that concentration, not a potency): 78.3%
For compound 3 the middle estimate is 33.3 percentage points below the measured one; the measured number lies above the stated range.
By their numbers in this assay, from the lowest: compounds 1 and 2 (each within the scatter of the next); then compound 3.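

Replacing the 4-fluorophenyl group with hydrogen on this aromatic carbon, para to a large group, gives a number 10.1 percentage points higher from compound 2 to compound 3 (beyond the scatter) in this assay. In this pair, then, the outer aromatic ring is not needed for inhibition at the concentration tested, and the smaller compound 3 inhibits more than compound 2 does. The earlier step changed only the amine at the end of the chain and stayed within the scatter, so this is the first change among these compounds to move the read-out beyond it, and no measurement here explains why the number rises.

From the compounds shown here alone, what a group of intermediate size would give at this place stays open: a single fluorine, a methyl or a methoxy group could show whether the read-out climbs steadily as the substituent shrinks or whether hydrogen is a special case. Going by these compounds, it is also open whether the same gain would appear with dimethylamino at the end of the chain, as in compound 1, in place of pyrrolidin-1-yl.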